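The source may report more compounds than this note shows. Statements on the series, on what has been measured and on what is new or still open speak of the compounds shown alone.

Of the compounds shown here, three sharing one core have so far been measured in a physicochemical assay for acid dissociation. Compound 1 (`COc1cccc(CNCCCNc2ccnc3cc(CC(C)C)ccc23)c1O`) gives 9.47, compound 2 (`COc1ccccc1Oc1ccc2c(NCCCNCc3cccc(OC)c3O)ccnc2c1`) gives 9.28, and compound 3 (`COc1cccc(CNCCCNc2ccnc3cc(Oc4ccc(C(C)(C)C)cc4)ccc23)c1O`) gives 9.28. Compound 3 therefore stands level with compound 2 at the digits shown, and all three numbers lie within the scatter of one another.

The next structure is compound 4 (`COc1cccc(CNCCCNc2ccnc3cc(Oc4ccc(Cl)cc4)ccc23)c1O`), which has chloro in place of tert-butyl on an aromatic carbon, para to a large group: chloro in place of tert-butyl on an aromatic carbon. Among the compounds with values here, none of the measured compounds carries chloro, so the data offer no direct reading for this group. The closest measured comparison exchanges the whole 2-methoxyphenyl group on the oxygen for 4-(tert-butyl)phenyl, and it shows no change at the digits printed from compound 2 to compound 3 (within the scatter). Replacing isobutyl on the core with an aromatic ether group also moved the number little, with a number 0.19 log units lower from compound 1 to compound 2 (within the scatter) and a number 0.19 log units lower from compound 1 to compound 3 (within the scatter).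

With steps this small behind it, the change is expected to produce no shift beyond the scatter in this assay, in either direction. The expected result is a number 0.03 log units lower from compound 3 to compound 4 (within the scatter). For compound 4 the estimated value is 9.25, with an expected range from 8.95 to 9.55.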

Compound 4, acid dissociation constant: 9.28
Beside the measured number, compound 4's estimate is 0.03 log units below it; measured number inside the range.
By their numbers in this assay, from the lowest: compounds 2, 3, 4 and 1 (each within the scatter of the next).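

In this assay, within the data shown here, chloro in place of tert-butyl on an aromatic carbon, para to a large group, gives no change at the digits printed from compound 3 to compound 4 (within the scatter) as the first direct reading of a change at this position, where a group of 4 heavy atoms gives way to a single chlorine atom. The other two new steps fit the same picture, with no change at the digits printed from compound 2 to compound 4 (within the scatter) when 4-chlorophenyl takes the place of 2-methoxyphenyl on the oxygen, and a number 0.19 log units lower from compound 1 to compound 4 (within the scatter) when 4-chlorophenoxy takes the place of isobutyl on the shared core, so among these four compounds none of the listed changes goes beyond the scatter. No measurement offered here accounts for this result.

From the compounds shown here alone, both groups tested at this position, tert-butyl and chloro, carry no hydrogen-bond donors or acceptors and no net charge, so it stays open whether an amine or a carboxylic acid there would take the number beyond the scatter. Also open, going by these compounds, is what a longer chain in place of the isobutyl on the core would do to the number.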